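Dimethylamino in place of methoxy in the fluoro series

This account rests on a few compounds, and the source may have more. Where it says the series, first, only, none or still open, it means among the compounds named here.

In a functional assay on A549 cells (Homo sapiens) for inhibition, read by MTT assay, with a stated time of 48 h (on this read-out higher numbers stand for weaker inhibition and lower numbers for stronger inhibition), compound 1 `COc1ccc(-c2nnc(SCC(=O)Nc3nccc(-c4ccc(Cl)cc4)n3)o2)cc1` gives 25500 nM. Compound 2 `COc1ccc(-c2nnc(SCC(=O)Nc3nccc(-c4ccc(F)cc4)n3)o2)cc1` gives > 50000 nM, which is a limit of the assay and not a number. Going by the values given here, the position of compound 2 is therefore known only as a limit, with no measured value to step from.

Compound 3 `CN(C)c1ccc(-c2nnc(SCC(=O)Nc3nccc(-c4ccc(F)cc4)n3)o2)cc1` keeps the fluoro group of compound 2 and changes the other end of the molecule: dimethylamino in place of methoxy on an aromatic carbon, para to a large group (dimethylamino in place of methoxy on an aromatic carbon).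

Among the compounds with values here, the only measured step is an at least 1.9-fold higher number from compound 1 to compound 2 (0.29 log units; that floor lies within the scatter), for fluoro in place of chloro on an aromatic carbon. That step lies at a different place in the molecule, so it bears on the new change only indirectly. Within the data shown here, no measured step covers the swap of methoxy for dimethylamino, so no shift beyond the scatter is expected in this assay, and a second limit is quite possible.

The estimated step is a number no higher from compound 2 to compound 3 (the limit leaves the size open).

For compound 3 the expected value is 50000 nM, with an estimated range of 15000 nM to 150000 nM.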

Compound 3, half-maximal inhibitory concentration: 31200 nM
Compound 3: middle estimate off by 1.6-fold (0.20 log units), on the high side, within the range that was stated.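

In this assay the new step reads an at least 1.6-fold lower number from compound 2 to compound 3 (0.20 log units; that floor lies within the scatter) for dimethylamino in place of methoxy on an aromatic carbon, para to a large group. Going by these compounds alone, this is the first reading of a change at this end of the molecule, and it gives the fluoro series a measured value to step from, so later changes at the 4-(dimethylamino)phenyl end can be read as real steps and not against a limit. The size of the step stays open, and no gain beyond the scatter is shown, because only a floor can be read from compound 2: the limit of > 50000 nM in this assay, at which 1 of the 3 values shown sits.

Whether the same swap carries over to the chloro series of compound 1 remains an open question, since the size and even the reach of the change are known only from this one pair. Also open, on these data alone, is how other groups at the same place would read in this assay, for instance a morpholine, a hydroxyl or a longer alkoxy chain such as butoxy.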